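Amino for Methoxy at the Fused Ring System

The source may hold more compounds than are shown below. What is called first, only, known or untested is meant among the compounds shown, and "the series" means these compounds.

Measured compounds:
compound 1, `CCCC[C@]1(CC)CS(=O)(=O)c2ccc(-c3ccccc3)cc2[C@@H](c2cccc(OC)c2)[C@H]1O`, 180 nM in an assay on cells for inhibition of ileal sodium/bile acid cotransporter (Homo sapiens); a lower number here means a stronger inhibitor, a higher number a weaker inhibitor
compound 2, `CCCC[C@]1(CC)CS(=O)(=O)c2ccc(OC)cc2[C@@H](c2ccccc2)[C@H]1O`, 55 nM in this assay

Compound 2 holds the lower of the two numbers, and its gap to compound 1 lies beyond the usual scatter. Compound 3, `CCCC[C@]1(CC)CS(=O)(=O)c2ccc(N)cc2[C@@H](c2ccccc2)[C@H]1O`, differs from compound 2 in one place: amino in place of methoxy on an aromatic carbon. Among the measured compounds shown here, no measured pair shows this exchange, so nothing anchors its size; a small step is expected, possibly none beyond the scatter, leaning slightly toward a higher number. The expected step is a 1.5-fold higher number from compound 2 to compound 3 (0.16 log units; within the scatter). Compound 3 is estimated at 80 nM, within a range from 25 nM to 250 nM.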

Compound 3, half-maximal inhibitory concentration: 68 nM
Beside the measured number, compound 3's estimate is 1.2-fold (0.07 log units) above it, and the stated range covers the measured number.
By their numbers in this assay, from the lowest: compounds 2 and 3 (each within the scatter of the next); then compound 1.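

In this assay, amino in place of methoxy on this aromatic carbon gives a 1.2-fold higher number from compound 2 to compound 3 (0.09 log units; within the scatter). The position therefore takes either group in this assay, although a hydrogen-bond donor enters and the carbon of methoxy leaves. Nothing available explains why the two groups read alike. Still open, as far as these compounds go, is whether a dimethylamino group, an acetamide or a carboxylic acid at this carbon would stay within the scatter of these two. Compound 1 differs from compound 2 in more than one place, so it adds nothing about this position.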